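The source may report more compounds than this note shows. Statements on the series, on what has been measured and on what is new or still open speak of the compounds shown alone.

Measured compounds:
compound 1, `CCc1nnn(Cc2ccc(C(F)(F)F)cc2)c1C(=O)N[C@@H](C)c1ccc(C(=O)O)cc1`: > 10000 nM
compound 2, `COc1ccc(Cn2nnc(-c3ccccc3)c2C(=O)N[C@@H](C)c2ccc(C(=O)O)cc2)cc1`: 9.3 nM

In a functional assay on CHO cells for antagonist activity at prostaglandin E2 receptor EP4 subtype (Homo sapiens), read by calcium flux, with a stated time of 15 min (on this read-out higher numbers stand for weaker inhibition and lower numbers for stronger inhibition), compound 1 gives only a limit, > 10000 nM, and no number is known for it. Compound 1 thus sits at the limit of > 10000 nM in this assay, at which 1 of the 2 values shown sits. In this assay compound 2 gives 9.3 nM. For the measured compounds named here, compound 2 and compound 1 differ in more than one place, so no single step between them can be drawn. Of this pair only the two values themselves can be spoken of.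

Compound 3, `C[C@H](NC(=O)c1c(C2=CCOCC2)nnn1Cc1ccc(C(F)(F)F)cc1)c1ccc(C(=O)O)cc1`, is not yet measured. It differs from compound 1 in one place: a group of 6 heavy atoms (5 carbon, 1 oxygen; one six-membered non-aromatic ring with 1 hetero atom) in place of a group of 2 heavy atoms (2 carbon; no ring), on an aromatic carbon. Going by the values given here, a ring group enters on the aromatic carbon of the shared core, and compound 2, the only compound with a number, also carries a ring group there. Compound 3 is therefore expected to inhibit more strongly than compound 1, with the step of an at least 33-fold lower number from compound 1 to compound 3 (1.52 log units; beyond the scatter) estimated as large, well beyond the scatter. The estimate for compound 3 in this assay is 300 nM, in a range from 30 nM to 3000 nM.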

Compound 3, half-maximal inhibitory concentration: 119 nM
Compound 3: middle estimate off by 2.5-fold (0.40 log units), on the high side, within the range that was stated.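

In this assay compound 1 gives > 10000 nM, a limit and not a number. For the compounds shown here, the single change on the aromatic carbon of the five-membered aromatic ring gives an at least 84-fold lower number from compound 1 to compound 3 (1.92 log units; beyond the scatter), the first step that can be read at one place. With everything else in the molecule unchanged, this carbon is thus a place where one substitution moves the read-out from the limit into the measurable range.

The compounds shown do not separate which part of the entering group goes with the step: the ring, its oxygen or its double bond. From the compounds shown here alone, how a butyl chain or an all-carbon cyclohexyl ring would stand at this position remains open, as does the true size of the step, whose starting end is only a limit.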